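Methyl for fluoro on a benzyl ether

This account rests on a few compounds, and the source may have more. Where it says the series, first, only, none or still open, it means among the compounds named here.

Compound 2 `CC(=O)c1cccc(OCc2ccc(F)cc2)c1` carries a fluoro group on its benzyl ring; in an assay on isolated protein for inhibition of Amine oxidase [flavin-containing] B (Homo sapiens), read by Amplex Red, with a stated time of 15 min (on this read-out higher numbers stand for weaker inhibition and lower numbers for stronger inhibition), compound 2 gives 86.4 nM. For the measured compounds named here, compound 1 `CC(=O)c1ccc(OCc2cccc(C)c2)cc1` is the only other compound measured, and in this assay compound 1 gives 86.3 nM, a number within the scatter of that of compound 2. Compound 3 `CC(=O)c1cccc(OCc2ccc(C)cc2)c1` is not yet measured; it differs from compound 2 by methyl in place of fluoro on an aromatic carbon. Going by the values given here, no comparable step is known here, so no change beyond the scatter is expected, and for compound 3 in this assay a value of 80 nM is estimated, between 25 nM and 260 nM, a step of a 1.1-fold lower number from compound 2 to compound 3 (0.03 log units; within the scatter) that is expected to stay within the scatter.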

Compound 3, half-maximal inhibitory concentration: 140 nM
Compound 3: the middle estimate sits 1.8-fold (0.24 log units) below what was measured, within the range that was stated.
By their numbers in this assay, from the lowest: compounds 1, 2 and 3 (each within the scatter of the next).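

Methyl in place of fluoro on an aromatic carbon, para to a large group, gives a 1.6-fold higher number from compound 2 to compound 3 (0.21 log units; within the scatter) in this assay. This first comparison of compounds differing in one place shows that, at this position, this exchange does not move the number beyond the scatter. No measurement here bears on why that is so. Going by these compounds, whether an amine, a carboxylic acid or a longer chain at this position would move the number beyond the scatter stays open. So does whether methyl in place of fluoro would act the same way elsewhere on the ring.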